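Ring amine substituents in the spiro series: sigma binding

The source may hold more compounds than are shown below. What is called first, only, known or untested is meant among the compounds shown, and "the series" means these compounds.

Compound 1 `COC1Cc2c(cnn2-c2ccccc2)C2(CCNCC2)O1` carries hydrogen on the amine nitrogen in the ring. In an assay for displacement of a labelled ligand from Sigma non-opioid intracellular receptor 1 (Cavia porcellus), read by scintillation counting, with a stated time of 180 min (on this read-out lower numbers stand for stronger inhibition and higher numbers for weaker inhibition), compound 1 gives > 1000 nM, which is a limit of the assay rather than a number (the limit of > 1000 nM in this assay, at which 1 of the 3 values shown sits). Compound 2 `COc1ccc(CN2CCC3(CC2)OC(OC)Cc2c3cnn2-c2ccccc2)cc1` gives 1.5 nM and compound 3 `COC1Cc2c(cnn2-c2ccccc2)C2(CCN(Cc3ccco3)CC2)O1` gives 2.2 nM; of the two measured numbers compound 3 holds the higher one, with compound 2 nearest, and the gap between them is within the scatter: a 1.5-fold higher number from compound 2 to compound 3 (0.17 log units; within the scatter). Both substituted compounds sit far from the unsubstituted one: an at least 660-fold lower number from compound 1 to compound 2 (2.82 log units; beyond the scatter) and an at least 450-fold lower number from compound 1 to compound 3 (2.65 log units; beyond the scatter).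

Compound 4 `COC1Cc2c(cnn2-c2ccccc2)C2(CCN(CCCc3ccccc3)CC2)O1` differs from compound 3 by phenethyl in place of furan-2-yl on a saturated chain carbon bound to an amine nitrogen in a ring. The step that bears on it most is the aryl swap on the same carbon, a 1.5-fold higher number from compound 2 to compound 3 (0.17 log units; within the scatter), which stayed within the scatter. The large steps of an at least 660-fold lower number from compound 1 to compound 2 (2.82 log units; beyond the scatter) and an at least 450-fold lower number from compound 1 to compound 3 (2.65 log units; beyond the scatter) concern adding a group to the bare nitrogen; compound 4 keeps a substituent on that nitrogen, so they do not apply. The expected step is therefore none beyond the scatter, a 1.1-fold lower number from compound 3 to compound 4 (0.04 log units; within the scatter). Compound 4 is estimated at 2 nM, within 0.7 nM to 6 nM.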

Compound 4, inhibition constant: 3.2 nM
Estimate against measurement, compound 4: 1.6-fold (0.20 log units) below; the range from low to high includes it.
By their numbers in this assay, from the lowest: compounds 2, 3 and 4 (each within the scatter of the next, the first and the last beyond it). At a limit, above all of these: compound 1.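

Replacing (furan-2-yl)methyl with 3-phenylpropyl on the amine nitrogen in the ring, a group with a phenyl ring in place of furan, gives no change that can be told from scatter in this assay: a 1.5-fold higher number from compound 3 to compound 4 (0.16 log units; within the scatter). Set against the 4-methoxybenzyl group of compound 2, the same 3-phenylpropyl group gives the first step among the substituted compounds that passes the scatter, and that step is only modest: a 2.1-fold higher number from compound 2 to compound 4 (0.33 log units; beyond the scatter). The gain over the bare nitrogen holds for this group too, an at least 310-fold lower number from compound 1 to compound 4 (2.49 log units; beyond the scatter), but compound 1 marks only a limit, so this size is a bound:  the limit of > 1000 nM in this assay, at which 1 of the 4 values shown sits.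

Open, on these data alone, is whether a plain butyl group on that nitrogen, without any aromatic ring, keeps numbers of this order. Also open, as far as these compounds go, is what a carboxylic acid or a second amine at the end of the chain would do.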